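A few compounds are considered here, and "the series" means these few. Any claim that something is new, unique, unknown or untested is made for them only; others in the source may bear on it.

Working notes on the series.

Within the data shown here, compound 1 `CC[C@@H]1C(=O)N(C)c2cnc(-n3ccc4cc(F)ccc43)nc2N1C1CCCC1` is the weaker of the two measured members: in a functional assay on K562 cells (Homo sapiens) for antiproliferative activity, read by CCK-8 assay, with a stated time of 72 h (on this read-out lower numbers stand for stronger inhibition of growth and higher numbers for weaker inhibition of growth), compound 1 gives 21200 nM, the highest number among the two values at hand. Compound 2 `CCC1C(=O)N(C)c2cnc(-n3ccc4cc(C(=O)NCC(C)C)ccc43)nc2N1c1ccn(C)n1` gives 5600 nM in this assay, a lower number than compound 1, and the gap between the two lies beyond the usual scatter. Compound 2 differs from compound 1 in more than one place, so its lower number cannot be tied to any single change.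

Compound 3 `CC[C@@H]1C(=O)N(C)c2cnc(-n3ccc4cc(C(=O)NC(C)C)ccc43)nc2N1C1CCCC1` is not yet measured. It differs from compound 1 in one place: isopropylcarbamoyl in place of fluoro on an aromatic carbon. Compound 2 also carries a carbamoyl group on the same fused ring, and its value of 5600 nM is the only hint available on what such a group does here.

Given that compound 2 gives 5600 nM, a step from compound 1 to compound 3 of about a 3.0-fold lower number from compound 1 to compound 3 (0.48 log units; beyond the scatter) toward stronger inhibition is expected in this assay, beyond the scatter. For compound 3 a value of 7000 nM is estimated, within a range of 2500 nM to 20000 nM.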

Compound 3, concentration for 50% growth inhibition: 786 nM
Compound 3: middle estimate off by 8.9-fold (0.95 log units), on the high side; the whole stated range lies above it.
By their numbers in this assay, from the lowest: compound 3; then compound 2; then compound 1.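

Among these compounds, at this aromatic carbon, the first change that can be read on its own has a large effect: in this assay, isopropylcarbamoyl in place of fluoro gives a 27-fold lower number from compound 1 to compound 3 (1.43 log units; beyond the scatter), with the rest of compound 1 kept. The position therefore accepts a much larger group than fluoro and, in this pair, the larger group goes with far stronger inhibition of growth; the entering group also brings a hydrogen-bond donor and a hydrogen-bond acceptor, which fluoro does not have. No measurement at hand shows which part of isopropylcarbamoyl accounts for the step.

Still open, on these data alone, is whether the amide hydrogen, the carbonyl or the isopropyl chain carries the step, a question that a dimethylcarbamoyl group, a carboxylic acid, an aminomethyl group or a longer alkyl chain on the same carbon could help settle. Compound 2 also carries a carbamoyl group, but it differs from compound 3 in more than one place, so the pair says nothing clear about the chain on the amide nitrogen.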